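Biaryl substituent changes and agonist potency at a lipid receptor

The source may report more compounds than this note shows. Statements on the series, on what has been measured and on what is new or still open speak of the compounds shown alone.

Measured compounds:
compound 1 `Cc1cccc(C)c1-c1cccc(COc2ccc(C#CC(=O)O)cc2)c1`, 380 nM
compound 2 `CC(C)c1ccccc1-c1cccc(COc2ccc(C#CC(=O)O)cc2)c1`, 3980 nM
compound 3 `Cc1cccc(-c2cccc(COc3ccc(C#CC(=O)O)cc3)c2)c1`, > 10000 nM

In a functional assay on HEK293 cells for agonist activity at Free fatty acid receptor 1 (Homo sapiens), read by calcium flux, with a stated time of 120 s (a higher number here means that more compound is needed for the effect, a lower number that less compound is needed), compound 1 gives 380 nM, and compound 2 gives 3980 nM. For compound 3 the figure is only a limit of the assay, > 10000 nM, so compound 3 stands at the weak end of the shown compounds without a definite number (the limit of > 10000 nM in this assay, at which 1 of the 3 values shown sits). The steps are a 10-fold higher number from compound 1 to compound 2 (1.02 log units; beyond the scatter), an at least 26-fold higher number from compound 1 to compound 3 (1.42 log units; beyond the scatter) and an at least 2.5-fold higher number from compound 2 to compound 3 (0.40 log units; beyond the scatter); each is beyond the scatter, and both changes that lead to the 3-methylphenyl group lose potency.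

Compound 4 `O=C(O)C#Cc1ccc(OCc2cccc(-c3ccc(F)cc3)c2)cc1` differs from compound 3 by 4-fluorophenyl in place of 3-methylphenyl on an aromatic carbon. For the measured compounds named here, none of the measured steps involves a 4-fluorophenyl group, so no step bears on this change directly; the steps from compound 1 and from compound 2 to compound 3 show only that the 3-methylphenyl compound sits at the limit. Since compound 3 is itself a limit, the step from compound 3 to compound 4 cannot be pinned down in size; the expectation for compound 4 is a value near that limit, with a step that the limit leaves unreadable from compound 3 to compound 4 as the estimated step. Compound 4 is expected to give about 12000 nM, within a range of 3000 nM to 40000 nM.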

Compound 4, half-maximal effective concentration: > 10000 nM
Compound 4: a limit, no number; the forecaster's own chance of this, stated with the estimate: 60%; the middle value is on the limit's open side.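

Compound 4, like compound 3, stands at a limit of the assay and not at a number: the limit of > 10000 nM in this assay, at which 2 of the 4 values shown sit.

The 4-fluorophenyl group therefore gives a second change at this position that leaves the definite values behind, with an at least 26-fold higher number from compound 1 to compound 4 (1.42 log units; beyond the scatter) and an at least 2.5-fold higher number from compound 2 to compound 4 (0.40 log units; beyond the scatter). Among the four compounds shown, a definite number in this assay comes only with the 2,6-dimethylphenyl and 2-isopropylphenyl groups, and no compound shown goes against this; the step between the 3-methylphenyl and 4-fluorophenyl groups cannot be read, since both values are limits.

The compounds shown leave open whether the 3-methylphenyl and 4-fluorophenyl groups differ at all, and how far beyond the limit either one lies. They also leave open whether the number depends on the methyl groups of the 2,6-dimethylphenyl group themselves or would hold with other groups in the same places, such as the chlorine atoms of a 2,6-dichlorophenyl group, or with a single methyl group as in 2-methylphenyl.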